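The compounds below may be only part of what the source reports. "The series", "measured", "known", "first", "only" and "open" are said of these compounds alone.

Compound 1 `Fc1ccc(C2=NN(c3nc(-c4ccccc4)cs3)C(c3cccs3)C2)cc1` was tested in a functional assay on MCF7 cells (Homo sapiens) for antiproliferative activity, read by MTT assay, with a stated time of 48 h (a higher number here means a weaker inhibitor, a lower number a stronger inhibitor), where compound 1 gives 2340 nM. Its only companion so far is compound 2 `Fc1ccc(C2=NN(c3nc(-c4ccc(C(F)(F)F)cc4)cs3)C(c3cccs3)C2)cc1`, which in this assay gives 1330 nM; the step of a 1.8-fold lower number from compound 1 to compound 2 (0.25 log units; within the scatter) leaves the two standing together. Compound 3 `Clc1ccc(C2=NN(c3nc(-c4ccccc4)cs3)C(c3cccs3)C2)cc1` differs from compound 1 by chloro in place of fluoro on an aromatic carbon. Within the data shown here, no measured step touches this exchange, and the one step known, from compound 1 to compound 2, was itself within the scatter. The expected step is therefore small, a 1.2-fold lower number from compound 1 to compound 3 (0.07 log units; within the scatter). Compound 3 is estimated at 2000 nM, between 800 nM and 5000 nM.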

Compound 3, half-maximal inhibitory concentration: 190 nM
Beside the measured number, compound 3's estimate is 11-fold (1.02 log units) above it, outside the stated range (below it).
By their numbers in this assay, from the lowest: compound 3; then compounds 2 and 1 (each within the scatter of the next).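

Replacing 4-fluorophenyl with 4-chlorophenyl gives a 12-fold lower number from compound 1 to compound 3 (1.09 log units; beyond the scatter) in this assay, so a change of a single atom at this position can move the number strongly. The one earlier step, made elsewhere on the molecule, stayed within the scatter, which makes this the first change shown that clearly separates two compounds. No evidence is available on what lies behind the difference between chloro and fluoro here. The compounds shown leave open whether bromo, methyl or methoxy on this carbon would behave like chloro or like fluoro. They also leave open how chloro here would combine with trifluoromethyl on the other phenyl ring.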